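This account rests on a few compounds, and the source may have more. Where it says the series, first, only, none or still open, it means among the compounds named here.

Measured in an ADME assay on L6 cells (Rattus norvegicus) for cytotoxicity, read by resazurin assay, with a stated time of 72 h; on this read-out lower numbers stand for stronger inhibition and higher numbers for weaker inhibition:
- compound 1 `OC(c1ccc(Cl)cc1)(c1ccc(Br)cc1)c1cccnc1`: 57000 nM
- compound 2 `COc1ccc(C(O)(c2ccc(Cl)cc2)c2cccnc2)cc1`: 68100 nM
- compound 3 `CC(C)Oc1ccc(C(O)(c2ccc(Cl)cc2)c2cccnc2)cc1`: 56600 nM

Compound 1 does not stand apart from the other two, since all three values lie within the usual scatter of one another. The next compound is compound 4 `OC(c1ccc(Cl)cc1)(c1cccnc1)c1nccs1`, in which 1,3-thiazol-2-yl takes the place of 4-bromophenyl on a saturated chain carbon bound to two aromatic carbons and an oxygen on a saturated carbon (1,3-thiazol-2-yl in place of 4-bromophenyl on a saturated chain carbon bound to two aromatic carbons and an oxygen on a saturated carbon).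

Three measured steps offer some guidance. Methoxy in place of bromo gave a 1.2-fold higher number from compound 1 to compound 2 (0.08 log units; within the scatter), isopropoxy in place of bromo gave a 1.0-fold lower number from compound 1 to compound 3 (0.00 log units; within the scatter), and isopropyl in place of methyl on the oxygen gave a 1.2-fold lower number from compound 2 to compound 3 (0.08 log units; within the scatter). Each of these changes a group on the ring, whereas compound 4 replaces the whole ring, so they bear on it only loosely. No step beyond the scatter is therefore expected in this assay, though the range stays wide. The expected change is a 1.3-fold higher number from compound 1 to compound 4 (0.12 log units; within the scatter). For compound 4 the estimated value is 75000 nM, within an expected range of 35000 nM to 150000 nM.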

Compound 4, half-maximal inhibitory concentration: > 100000 nM
Compound 4 gave a limit, no number (the forecaster's own chance of this, stated with the estimate: 15%); middle value at least 1.3-fold (0.12 log units) away from the limit.
By their numbers in this assay, from the lowest: compounds 3, 1 and 2 (each within the scatter of the next). At a limit, above all of these: compound 4.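

In this assay, compound 4 gives > 100000 nM, which is a limit of the assay and not a number. Going by these compounds, the step reads as an at least 1.7-fold higher number from compound 1 to compound 4 (0.24 log units; that floor lies within the scatter), so its true size stays unknown, and the result cannot say whether replacing the whole ring matters much or little. The earlier steps only changed a group on the ring and all stayed within the scatter, whereas this change puts a different ring on the saturated chain carbon and gives the one result shown that cannot be placed as a number: the limit of > 100000 nM in this assay, at which 1 of the 4 values shown sits.

1,3-thiazol-2-yl differs from 4-bromophenyl in ring size, hetero atoms and hydrogen-bond acceptors all at once, and the compounds shown do not separate these. On these data alone, how an amine or a longer chain in the same place would read in this assay also remains open.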